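From a hydroxymethyl sulfone to a cyclopropyl sulfonamide

This account rests on a few compounds, and the source may have more. Where it says the series, first, only, none or still open, it means among the compounds named here.

Measured so far in an ADME assay on microsomes from liver (Homo sapiens) for metabolic stability, read by LC-MS, with a stated time of 40 min, tested at 0.5 uM; a higher number here means faster removal of the compound, a lower number slower removal:
- compound 1, `CC(C)(CO)S(=O)(=O)c1cccc(NC(=O)c2cccnc2N2CCC3(CC2)CC3)c1`: 154 mL.min-1.g-1
- compound 2, `CC(C)(CO)Nc1ccc(C(=O)Nc2cccc(S(=O)(=O)NC3CCCC3)n2)c(N2CCC3(CC2)CC3)c1`: reported only as a limit, > 399 mL.min-1.g-1

Among the measured compounds shown here, compound 1 is the only compound with an actual number in this assay; there compound 1 gives 154 mL.min-1.g-1. For compound 2 the result in this assay is a limit of the assay rather than a number, > 399 mL.min-1.g-1. For the measured compounds named here, this is reflected in the limit of > 399 mL.min-1.g-1 in this assay, at which 1 of the 2 values shown sits, so no step between two measured compounds can be drawn, and compound 1 stands as the single reference point.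

Compound 3, `O=C(Nc1cccc(S(=O)(=O)NC2CC2)c1)c1cccnc1N1CCC2(CC1)CC2`, has not yet been measured. It differs from compound 1 in one place: cyclopropylamino in place of 1-(hydroxymethyl)-1-methylethyl on a sulfonyl sulfur. The shared core of compound 1 and the amide that connects the two ring systems are kept unchanged. Going by the values given here, no measured pair shows what this kind of exchange does in this assay, so the expectation rests on compound 1 alone. The step of a 1.2-fold higher number from compound 1 to compound 3 (0.09 log units; within the scatter) is expected to be small, at most slightly beyond the usual scatter and in the direction of faster removal. Compound 3 is therefore estimated at 190 mL.min-1.g-1, with a range from 80 mL.min-1.g-1 to 400 mL.min-1.g-1.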

Compound 3, intrinsic clearance in microsomes: > 399 mL.min-1.g-1
Compound 3 gave a limit, no number; the forecaster's own chance of this, stated with the estimate: 15%; middle value at least 2.1-fold (0.32 log units) from the limit.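

With the shared core and the connecting amide kept, cyclopropylamino in place of 1-(hydroxymethyl)-1-methylethyl on a sulfonyl sulfur gives an at least 2.5-fold higher number from compound 1 to compound 3 (0.41 log units; beyond the scatter) in this assay. Among the compounds shown here, this is the first step that can be read between two compounds here, and it shows that the group on the sulfonyl sulfur can shift this read-out beyond the usual scatter, in the direction of faster removal. Compound 3 is reported only as a limit of the assay, > 399 mL.min-1.g-1, so the step gives a smallest possible size and not a true size, and the results shown now gather at the top of the measurable range: the limit of > 399 mL.min-1.g-1 in this assay, at which 2 of the 3 values shown sit.

The exchange replaces the chain with a ring and also brings a nitrogen onto the sulfur, so the compounds shown leave open which of these two differences carries the step. A plain cyclopropyl group on the sulfonyl sulfur, with no nitrogen, would separate the two, and a dimethylamino group there would show how a sulfonamide without a ring reads in this assay.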